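Swapping methyl for methoxy on a thiourea series

A few compounds are considered here, and "the series" means these few. Any claim that something is new, unique, unknown or untested is made for them only; others in the source may bear on it.

Three thiourea compounds sharing one core have been tested in a functional assay on HepG2 cells (Homo sapiens) for antiproliferative activity, read by MTT assay; a higher number here means a weaker inhibitor, a lower number a stronger inhibitor. Compound 1 `CNC(=O)c1ccc(Oc2cccc(NC(=S)Nc3ccc(C)cc3)c2)nc1` gives 65400 nM, the highest of the three numbers. Compound 2 `CNC(=O)c1ccc(Oc2cccc(NC(=S)Nc3ccc(F)c(F)c3)c2)nc1` gives 26700 nM and compound 3 `CNC(=O)c1ccc(Oc2cccc(NC(=S)Nc3cccc(C(F)(F)F)c3)c2)nc1` gives 23300 nM. The known steps, a 2.4-fold lower number from compound 1 to compound 2 (0.39 log units; beyond the scatter) and a 2.8-fold lower number from compound 1 to compound 3 (0.45 log units; beyond the scatter), both exchange the whole aryl group and both lower the number modestly. Compound 4 `CNC(=O)c1ccc(Oc2cccc(NC(=S)Nc3ccc(OC)cc3)c2)nc1` differs from compound 1 more gently: methoxy in place of methyl on an aromatic carbon. Going by the values given here, no measured step tests this exchange directly, so the expectation for compound 4 rests only on how little the aryl swaps moved the number. A step of a 1.1-fold lower number from compound 1 to compound 4 (0.04 log units; within the scatter) is expected, essentially none beyond the scatter. Compound 4 is thus estimated at 60000 nM, between 25000 nM and 140000 nM.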

Compound 4, half-maximal inhibitory concentration: 85300 nM
For compound 4 the middle estimate is 1.4-fold (0.15 log units) below the measured one, within the range that was stated.
By their numbers in this assay, from the lowest: compounds 3 and 2 (each within the scatter of the next); then compounds 1 and 4 (each within the scatter of the next).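

In this assay the step of a 1.3-fold higher number from compound 1 to compound 4 (0.12 log units; within the scatter) shows that methoxy in place of methyl, on this aromatic carbon para to a large group, leaves the number essentially unmoved. Exchanging the whole aryl group still counts for more, as a 3.7-fold higher number from compound 3 to compound 4 (0.56 log units; beyond the scatter) and a 3.2-fold higher number from compound 2 to compound 4 (0.50 log units; beyond the scatter) show, while this small exchange does not. No measured evidence explains these differences.

The compounds shown leave open whether a hydroxyl, an amine or a chlorine on this same carbon would move the number. On these data alone, a longer chain, such as ethoxy, also remains open.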